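Swapping Methoxyphenyl for Fluorophenyl on a Shared Core

A few compounds are considered here, and "the series" means these few. Any claim that something is new, unique, unknown or untested is made for them only; others in the source may bear on it.

The account follows a single change from compound 1, `CCC1=C(O)c2c(oc(-c3ccc(OC)cc3)cc2=O)C(CC)(CC)C1=O`, to compound 3, `CCC1=C(O)c2c(oc(-c3ccccc3F)cc2=O)C(CC)(CC)C1=O`. In a functional assay on KB cells (Homo sapiens) for antiproliferative activity, read by sulforhodamine B assay, with a stated time of 3 days (on this read-out lower numbers stand for an effect already at smaller amounts and higher numbers for an effect only at larger amounts of compound), compound 1 gives 17.7 uM. Within this set that is the only numerical result; the other value recorded is a limit. Compound 2, `CCC1=C(O)c2c(oc(-c3cccc(OC(F)(F)F)c3)cc2=O)C(CC)(CC)C1=O`, reaches only a limit of the assay in this assay, given as > 47.4 uM. Among the compounds with values here, the record therefore consists of the limit of > 47.4 uM in this assay, at which 1 of the 2 values shown sits, together with the single number for compound 1, and no step between two measured compounds can be drawn from it.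

Compound 3 differs from compound 1 by 2-fluorophenyl in place of 4-methoxyphenyl on an aromatic carbon. Within the data shown here, with no measured step to lean on, the direction and size must be estimated from the change alone. A move toward higher concentrations is expected, and the step from compound 1 to compound 3 in this assay is estimated at a 1.7-fold higher number from compound 1 to compound 3 (0.23 log units; within the scatter). Compound 3 is accordingly expected to give roughly 30 uM in this assay, with a likely span from 10 uM to 70 uM, and a fair chance that only a limit is returned.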

Compound 3, concentration for half-maximal effect: > 56.2 uM
Compound 3: no number, only a limit (the forecaster's own chance of this, stated with the estimate: 35%); at least 1.8-fold (0.27 log units) between middle value and limit.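

With this change, the position next to the ring oxygen gains its first readable step, an at least 3.1-fold higher number from compound 1 to compound 3 (0.50 log units; beyond the scatter), and 2-fluorophenyl in place of 4-methoxyphenyl moves the result from a number to a limit. In this assay, compound 1 gives 17.7 uM, and it remains the only compound shown with a number. Neither other aryl group gives a number at this position, so among the three compounds shown, only the one with 4-methoxyphenyl has a measured value, while the other two end at limits: the limit of > 56.2 uM in this assay, at which 1 of the 3 values shown sits.

Within the data shown here, the true size of the step remains unknown, as does any order between compound 2 and compound 3, and no step between those two can be read. Because 2-fluorophenyl differs from 4-methoxyphenyl in both the substituent and its place on the phenyl ring, the shown compounds cannot separate these two parts of the change; that would take a comparison with 4-fluorophenyl or 2-methoxyphenyl, while an amine on the same ring would test a different kind of substituent: the limit of > 47.4 uM in this assay, at which 1 of the 3 values shown sits.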